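Side group size across the series

This account rests on a few compounds, and the source may have more. Where it says the series, first, only, none or still open, it means among the compounds named here.

In a functional assay on HepG2 cells (Homo sapiens) for inhibition, read by MTT assay, with a stated time of 48 h (on this read-out lower numbers stand for stronger inhibition and higher numbers for weaker inhibition), compound 1 (`COc1ccc(N(C)c2nc(C)nc3ccccc23)cc1C(=O)OCCC[Se]C#N`) gives 340 nM, compound 2 (`COc1ccc(N(C)c2nc(C)nc3ccccc23)cc1OCC[Se]C#N`) gives 14 nM and compound 3 (`COc1ccc(N(C)c2nc(C)nc3ccccc23)cc1OCCCC[Se]C#N`) gives 6460 nM, the highest number of the three. Compound 4 (`COc1ccc(N(C)c2nc(C)nc3ccccc23)cc1C[Se]C#N`) is unmeasured and differs from compound 3 by a group of 4 heavy atoms (2 carbon, 1 nitrogen, 1 selenium; no ring) in place of a group of 8 heavy atoms (5 carbon, 1 nitrogen, 1 oxygen, 1 selenium; no ring), on an aromatic carbon.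

The closest guide is a 460-fold higher number from compound 2 to compound 3 (2.66 log units; beyond the scatter), a large step that came with the larger group. Also large are a 24-fold lower number from compound 1 to compound 2 (1.39 log units; beyond the scatter) and a 19-fold higher number from compound 1 to compound 3 (1.28 log units; beyond the scatter), so changes to this group have moved the number strongly. Within the data shown here, the group entering compound 4 holds no oxygen, unlike the one in compound 2, which makes that guide only partial. The expected change is a large drop, a 43-fold lower number from compound 3 to compound 4 (1.63 log units; beyond the scatter). For compound 4 the estimated value is 150 nM, with an expected range of 15 nM to 2000 nM.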

Compound 4, half-maximal inhibitory concentration: 1110 nM
The estimate for compound 4 lay 7.4-fold (0.87 log units) below the measured number; measured number inside the range.
By their numbers in this assay, from the lowest: compound 2; then compound 1; then compound 4; then compound 3.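

The group of 4 heavy atoms, the smallest in the series, shows that shortening alone gives only a limited gain, with a 5.8-fold lower number from compound 3 to compound 4 (0.76 log units; beyond the scatter). It does not reach the level of the group with one more oxygen, as shown by a 79-fold higher number from compound 2 to compound 4 (1.90 log units; beyond the scatter). Even the largest group, of 9 heavy atoms, gives the lower number, with a 3.3-fold higher number from compound 1 to compound 4 (0.51 log units; beyond the scatter), so the number does not follow group size among these compounds.

Going by these compounds, whether an amine in place of the oxygen of compound 2 would hold its low number stays open. Nothing available accounts for these differences.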